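Moving the methoxy group on the benzamide of a flavonol

The source may report more compounds than this note shows. Statements on the series, on what has been measured and on what is new or still open speak of the compounds shown alone.

Measured compounds in a functional assay on HeLa cells (Homo sapiens) for antiproliferative activity, read by CCK-8 assay, with a stated time of 72 h; a lower number here means a stronger inhibitor, a higher number a weaker inhibitor:
compound 1 `O=C(Nc1cccc(-c2oc3cc(-c4ccc(F)cc4)ccc3c(=O)c2O)c1)c1ccccc1F` gives 5630 nM
compound 2 `COc1ccc(C(=O)Nc2cccc(-c3oc4cc(-c5ccc(F)cc5)ccc4c(=O)c3O)c2)cc1` gives 4820 nM
compound 3 `O=C(Nc1cccc(-c2oc3cc(-c4ccc(F)cc4)ccc3c(=O)c2O)c1)c1ccc(Cl)cc1` gives 3670 nM

Compound 2 stands second highest of the three numbers, and all three lie within the usual scatter of one another: the steps of a 1.2-fold lower number from compound 1 to compound 2 (0.07 log units; within the scatter), a 1.5-fold lower number from compound 1 to compound 3 (0.19 log units; within the scatter) and a 1.3-fold lower number from compound 2 to compound 3 (0.12 log units; within the scatter) are each within the scatter. Compound 4 `COc1ccccc1C(=O)Nc1cccc(-c2oc3cc(-c4ccc(F)cc4)ccc3c(=O)c2O)c1` has not been measured. It differs from compound 2 by 2-methoxyphenyl in place of 4-methoxyphenyl on a carbonyl carbon. Among the measured compounds shown here, the only measured steps that bear on this change are those that alter the same aryl group on the carbonyl carbon, a 1.2-fold lower number from compound 1 to compound 2 (0.07 log units; within the scatter) and a 1.5-fold lower number from compound 1 to compound 3 (0.19 log units; within the scatter), and both are within the scatter; no measured pair tests the move of a methoxy group from one ring position to another. On that basis compound 4 is expected to show no step beyond the scatter, which as a step reads a 1.0-fold higher number from compound 2 to compound 4 (0.02 log units; within the scatter). Compound 4 is therefore estimated at 5000 nM, with a range from 2500 nM to 10000 nM.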

Compound 4, half-maximal inhibitory concentration: 14100 nM
Compound 4: middle estimate off by 2.8-fold (0.45 log units), on the low side; measured number outside the range, above it.
By their numbers in this assay, from the lowest: compounds 3, 2 and 1 (each within the scatter of the next); then compound 4.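

In this assay, among the compounds shown here, the methoxy group is not interchangeable between these two ring positions: the change from 4-methoxyphenyl to 2-methoxyphenyl on the carbonyl carbon keeps the same atoms yet gives a 2.9-fold higher number from compound 2 to compound 4 (0.47 log units; beyond the scatter), the first step in this set beyond the scatter. The 2-methoxyphenyl group also separates from the 4-chlorophenyl group, with a 3.8-fold higher number from compound 3 to compound 4 (0.58 log units; beyond the scatter), and from the 2-fluorophenyl group, with a 2.5-fold higher number from compound 1 to compound 4 (0.40 log units; beyond the scatter), so compound 1 goes against any reading that a group at that ring position alone raises the number. No available evidence accounts for this difference.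

The compounds shown leave open whether a 2-chlorophenyl group would part from the 4-chlorophenyl group of compound 3 in the same way. They also leave open whether a 2-ethoxyphenyl or 2-aminophenyl group would stand with compound 4 or with compound 1.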